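Swapping methyl for methoxy on a shared core

The compounds below may be only part of what the source reports. "The series", "measured", "known", "first", "only" and "open" are said of these compounds alone.

Compound 1 `Cc1ncnc2c1c(I)cn2[C@@H]1O[C@H](CO)[C@@H](O)[C@H]1O` gives 12200 nM in a functional assay on A549 cells (Homo sapiens), read by MTT assay, with a stated time of 72 h; on this read-out higher numbers stand for weaker inhibition and lower numbers for stronger inhibition.
Compound 2 `Cc1ncnc2c1c(-c1ccoc1)cn2[C@@H]1O[C@H](CO)[C@@H](O)[C@H]1O` reaches only the limit > 20000 nM in this assay.
Compound 3 `Cc1ncnc2c1c(-c1cccs1)cn2[C@@H]1O[C@H](CO)[C@@H](O)[C@H]1O` reaches only the limit > 20000 nM in this assay.

Going by the values given here, compound 1 holds the only real number here; the other two values are limits, as the limit of > 20000 nM in this assay, at which 2 of the 3 values shown sit, records. The measured steps of an at least 1.6-fold higher number from compound 1 to compound 2 (0.21 log units; that floor lies within the scatter) and an at least 1.6-fold higher number from compound 1 to compound 3 (0.21 log units; that floor lies within the scatter) each replace the iodo group, not the methyl, so neither bears on the change studied now. Compound 4 `COc1ncnc2c1c(I)cn2[C@@H]1O[C@H](CO)[C@@H](O)[C@H]1O` differs from compound 1 by methoxy in place of methyl on an aromatic carbon. Among the compounds with values here, no measured step tests this change, so no step beyond the scatter is expected, and the estimate for compound 4 in this assay is 14000 nM with a range from 5000 nM to 40000 nM. That estimate means the step of a 1.1-fold higher number from compound 1 to compound 4 (0.06 log units; within the scatter) is expected to stay within the scatter.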

Compound 4, half-maximal inhibitory concentration: > 20000 nM
Compound 4: only a limit was reported (the forecaster's own chance of this, stated with the estimate: 35%); middle value at least 1.4-fold (0.15 log units) from the limit.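

Going by these compounds alone, the first change at this position, methoxy in place of methyl next to the ring nitrogen, gives an at least 1.6-fold higher number from compound 1 to compound 4 (0.21 log units; that floor lies within the scatter) in this assay and so shows no step beyond the scatter, though it does not rule out a larger one. Within the data shown here, compound 4 joins compounds 2 and 3 at a limit, leaving compound 1 as the only compound with a real number: the limit of > 20000 nM in this assay, at which 3 of the 4 values shown sit.

From the compounds shown here alone, the true value of compound 4 stays open. So does whether an amine or an ethoxy group in place of the methyl would give a readable number.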